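Methoxy for Chloro on the Anilino Ring of Compound 3

A few compounds are considered here, and "the series" means these few. Any claim that something is new, unique, unknown or untested is made for them only; others in the source may bear on it.

Three compounds have values in an ADME assay on HaCaT cells (Homo sapiens) for antiproliferative activity, read by MTT assay, with a stated time of 48 h; on this read-out lower numbers stand for stronger inhibition and higher numbers for weaker inhibition:

Compound 1 `COc1ccc(N/C=C\C(=O)c2cn(-c3ccccc3)nc2-c2ccccc2)cc1` gives > 50000 nM, which is a limit of the assay and not a number.
Compound 2 `COc1ccc(N/C=C\C(=O)c2cn(-c3ccccc3)nc2-c2ccc(F)cc2)cc1` gives 19600 nM.
Compound 3 `COc1cc(-c2nn(-c3ccccc3)cc2C(=O)/C=C\Nc2ccc(Cl)cc2)cc(OC)c1OC` gives 30200 nM.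

Compound 3 thus stands highest of the two numbers, with compound 2 nearest, though that gap lies within the scatter, and compound 1 stands at a limit (the limit of > 50000 nM in this assay, at which 1 of the 3 values shown sits). Among the measured compounds shown here, the only measured step is an at least 2.5-fold lower number from compound 1 to compound 2 (0.40 log units; beyond the scatter), fluoro in place of hydrogen, which sits on a different ring from the change now considered and so bears on it only loosely. Compound 4 `COc1ccc(N/C=C\C(=O)c2cn(-c3ccccc3)nc2-c2cc(OC)c(OC)c(OC)c2)cc1` differs from compound 3 by methoxy in place of chloro on an aromatic carbon; compounds 1 and 2 already carry this methoxy-bearing anilino ring, and their values do not fall far from compound 3. For the measured compounds named here, no measured step addresses methoxy against chloro, so for compound 4 a step of a 1.0-fold lower number from compound 3 to compound 4 (0.00 log units; within the scatter) in this assay is expected, none beyond the scatter. Compound 4 is therefore estimated at 30000 nM, between 12000 nM and 75000 nM.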

Compound 4, half-maximal inhibitory concentration: > 50000 nM
Compound 4 gave a limit, no number; the forecaster's own chance of this, stated with the estimate: 30%; at least 1.6-fold (0.22 log units) between middle value and limit.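

With 4-methoxyphenyl in place of 4-chlorophenyl, this assay shows an at least 1.6-fold higher number from compound 3 to compound 4 (0.21 log units; that floor lies within the scatter), so this change gives no sign of stronger inhibition but does not establish weaker inhibition either. With the (4-methoxyphenyl)amino group held constant, 3,4,5-trimethoxyphenyl in place of 4-fluorophenyl gives an at least 2.5-fold higher number from compound 2 to compound 4 (0.40 log units; beyond the scatter), a step that is readable even though compound 4 gives only a limit. The step between the two compounds at the limit cannot be read, and that limit now recurs in the set: the limit of > 50000 nM in this assay, at which 2 of the 4 values shown sit.

From the compounds shown here alone, how far compound 4 lies beyond its limit stays open, and with it the true size of the change from chloro to methoxy. Also open, going by these compounds, is whether an amine or a carboxylic acid in the same place would lower the number.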